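The compounds below may be only part of what the source reports. "The series", "measured", "known", "first", "only" and "open" are said of these compounds alone.

Compound 1 `CC/C=C/C(=O)Nc1cc2c(N3CCc4ccccc43)ncnc2cc1O[C@@H]1CCOC1`, compound 2 `CC(C)/C=C/C(=O)Nc1cc2c(N3CCc4ccccc43)ncnc2cc1O[C@@H]1CCOC1` and compound 3 `C/C=C/C(=O)Nc1cc2c(N3CCCc4ccccc43)ncnc2cc1OC` were each tested in a functional assay on PC-3 cells (Homo sapiens) for antiproliferative activity, read by MTT assay, with a stated time of 72 h; a lower number here means a stronger inhibitor, a higher number a weaker inhibitor. Compound 1 gives 9590 nM, compound 2 gives 11200 nM, and compound 3 gives 7520 nM. From compound 1 to compound 2 the change is methyl in place of hydrogen on a saturated chain carbon bound to a double-bonded chain carbon and a saturated chain carbon, and this gave a 1.2-fold higher number from compound 1 to compound 2 (0.07 log units; within the scatter). The difference between the core of compound 3 and the core of compound 1 is not broken down here. Compound 4 `CC/C=C/C(=O)Nc1cc2c(N3CCCc4ccccc43)ncnc2cc1OC` is not yet measured; it carries methyl in place of hydrogen on a saturated chain carbon bound to a double-bonded chain carbon. This is the same kind of change as before, though here the place is bound only to a double-bonded chain carbon and not also to a saturated chain carbon. A similar small step is expected, a 1.1-fold higher number from compound 3 to compound 4 (0.05 log units; within the scatter), because a 1.2-fold higher number from compound 1 to compound 2 (0.07 log units; within the scatter) stayed within the scatter. Compound 4 is therefore expected to give 8500 nM, likely between 4000 nM and 18000 nM.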

Compound 4, half-maximal inhibitory concentration: 6310 nM
Estimate against measurement, compound 4: 1.3-fold (0.13 log units) above; the range from low to high includes it.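

In this assay, the methyl that turns prop-1-en-1-yl into but-1-en-1-yl gave a 1.2-fold lower number from compound 3 to compound 4 (0.08 log units; within the scatter). The two steps point in opposite directions, but both are so small that this opposite sign carries no meaning, and on these two cores the change behaves alike: the same change on two cores in this assay, a 1.2-fold higher number (0.07 log units; within the scatter) from compound 1 to compound 2 and a 1.2-fold lower number (0.08 log units; within the scatter) from compound 3 to compound 4, 1.4-fold (0.14 log units) apart, within the scatter of two such steps. This shows only that adding this methyl left the number within the scatter on both cores; two pairs do not show that it would stay so small on a further core, or set a rule for the series.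

The compounds shown leave open whether a longer chain, or a chain carrying an amine, would give a step beyond the scatter. They also leave open how each difference between the two cores acts on its own.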